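Methyl on the indole nitrogen: a step without a reading

A few compounds are considered here, and "the series" means these few. Any claim that something is new, unique, unknown or untested is made for them only; others in the source may bear on it.

Measured so far:
compound 1 `C(=C\c1ccc2[nH]ccc2c1)\c1ccc2ccccc2c1` — > 5000 nM
compound 2 `Cn1ccc2cc(/C=C\c3ccc4ccccc4c3)ccc21` — > 5000 nM
compound 3 `COc1cc(/C=C/c2ccc3[nH]ccc3c2)cc(OC)c1OC` — 470 nM

Of the compounds shown here, three have been tested in a functional assay on A549 cells (Homo sapiens) for inhibition; a higher number here means a weaker inhibitor, a lower number a stronger inhibitor. For compound 1 the result is only a limit of the assay, > 5000 nM, not a number. For compound 2 the result is likewise a limit, > 5000 nM. For the measured compounds named here, compound 3 is the one compound with a real number, 470 nM. The other two results are limits, as noted in the limit of > 5000 nM in this assay, at which 2 of the 3 values shown sit.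

Compound 1 and compound 2 differ in one place only: methyl in place of hydrogen on an aromatic nitrogen. Going by these compounds, because both results are limits, the step that the two limits leave unreadable from compound 1 to compound 2 cannot be read; its size is unknown.

Compound 3 and compound 1 differ by more than one place, and the difference between the two cores is not broken down here.

The not yet measured compound 4, `COc1cc(/C=C/c2ccc3c(ccn3C)c2)cc(OC)c1OC`, carries the same change relative to compound 3: methyl in place of hydrogen on an aromatic nitrogen. Going by the values given here, the only earlier example of this change, from compound 1 to compound 2, gives no readable size, so there is no measured guide for the step from compound 3 to compound 4.

For compound 4 in this assay a step of a 1.7-fold higher number from compound 3 to compound 4 (0.23 log units; within the scatter) is therefore expected only as a broad guess, resting on compound 3 giving 470 nM and on the earlier step being unreadable. Compound 4 is estimated at 800 nM, with a plausible range from 250 nM to 3000 nM.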

Compound 4, half-maximal inhibitory concentration: 470 nM
The estimate for compound 4 lay 1.7-fold (0.23 log units) above the measured number; the range from low to high includes it.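

In this assay, methyl in place of hydrogen on an aromatic nitrogen gives no change at the digits printed from compound 3 to compound 4 (within the scatter), so on the core of compound 3 this replacement leaves the measured result as it was. The same change on the other core, going from compound 1 to compound 2, cannot be read, because both results there are limits of the assay and not numbers: the limit of > 5000 nM in this assay, at which 2 of the 4 values shown sit. The series therefore holds a single readable example of this change, which shows that it is tolerated on one core but does not show that it would behave in the same way on the core of compound 1, or on any other core.

Among the compounds shown, that nitrogen carries only hydrogen or methyl, so it remains open whether a longer chain such as propyl, or a chain ending in an amine or a carboxylic acid, would leave the result in this assay as unchanged as methyl does. Also open, going by these compounds, is whether compound 1 and compound 2 differ from each other at all, as neither has a number that could be compared.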